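This account rests on a few compounds, and the source may have more. Where it says the series, first, only, none or still open, it means among the compounds named here.

Three compounds sharing one core were measured in a functional assay on HeLa cells (Homo sapiens) for inhibition, read by MTT assay, with a stated time of 48 h; a lower number here means a stronger inhibitor, a higher number a weaker inhibitor. Compound 1 `CCOC(=O)C1=C(N/C=N/c2ncc(-c3ccccc3)s2)Nc2[nH]nc(C)c2C1c1ccc(N(C)C)cc1` gives 15400 nM, compound 2 `CCOC(=O)C1=C(N/N=C(\c2ccc([N+](=O)[O-])cc2)N2CCN(c3ccc(F)cc3)CC2)Nc2[nH]nc(C)c2C1c1ccc(N(C)C)cc1` gives 87000 nM, and compound 3 `CCOC(=O)C1=C(NN=C(C(C)=O)C(C)=O)Nc2[nH]nc(C)c2C1c1ccc(N(C)C)cc1` gives 17000 nM. Compound 3 thus has the second highest of the three numbers: its value and that of compound 1 lie within the scatter of each other, while compound 2 shows a higher number that lies beyond it. The unmeasured compound 4 `CCOC(=O)C1=C(N)Nc2[nH]nc(C)c2C1c1ccc(N(C)C)cc1` differs from compound 3 in one place: a hydrogen atom in place of a group of 8 heavy atoms (5 carbon, 1 nitrogen, 2 oxygen; no ring), on an amine nitrogen. Going by the values given here, no step between measured compounds is known here, so the outcome of this change is uncertain; in this assay a modest move toward a higher number, or none beyond the scatter, is expected. Compound 4 is estimated at 25000 nM, within 8000 nM to 80000 nM. The expected step is a 1.5-fold higher number from compound 3 to compound 4 (0.17 log units; within the scatter).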

Compound 4, half-maximal inhibitory concentration: 6220 nM
The estimate for compound 4 lay 4.0-fold (0.60 log units) above the measured number; the whole stated range lies above it.
By their numbers in this assay, from the lowest: compound 4; then compounds 1 and 3 (each within the scatter of the next); then compound 2.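

In this assay the group of 8 heavy atoms on the amine nitrogen proves unnecessary for this level of inhibition: hydrogen in its place gives a 2.7-fold lower number from compound 3 to compound 4 (0.44 log units; beyond the scatter) and thus a stronger inhibitor. Going by these compounds alone, this is the first step that can be read at this position, and it shows that removing the whole group, with its 3 double bonds, costs nothing here. No measured evidence accounts for this step. On these data alone, whether a small group on this nitrogen, such as a methyl or an acetyl group, would keep this gain remains open.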